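Shortening a Side Chain: Two Cores, One Kind of Change

This account rests on a few compounds, and the source may have more. Where it says the series, first, only, none or still open, it means among the compounds named here.

In a functional assay on Raji cells (Homo sapiens) (on this read-out higher numbers stand for weaker inhibition and lower numbers for stronger inhibition), compound 1 `CCCCCCCCc1cn([C@H]2C[C@@H]3OP(=O)(O)OC[C@H]3O2)c(=O)[nH]c1=O` gives 165 ug/mL. Compound 2 `CCCCCCc1cn([C@H]2C[C@@H]3OP(=O)(O)OC[C@H]3O2)c(=O)[nH]c1=O` carries hydrogen in place of ethyl on a saturated chain carbon, six bonds along the chain from an aromatic carbon and in this assay gives only a limit, > 500 ug/mL. The step of an at least 3.0-fold higher number from compound 1 to compound 2 (0.48 log units; beyond the scatter) therefore runs up to the limit of > 500 ug/mL in this assay, at which 1 of the 3 values shown sits. Compound 3 `CCCCCc1cn([C@H]2C[C@H](O)[C@@H](CO)O2)c(=O)[nH]c1=O` is built on a different core; the difference between the two cores is not broken down here. In this assay compound 3 gives 334 ug/mL, a weaker inhibition than compound 1. Compound 4 `CCCc1cn([C@H]2C[C@H](O)[C@@H](CO)O2)c(=O)[nH]c1=O` carries hydrogen in place of ethyl on a saturated chain carbon, three bonds along the chain from an aromatic carbon. This is the same kind of change as from compound 1 to compound 2, though there the cut lies six bonds along the chain from an aromatic carbon and here three bonds along the chain from an aromatic carbon. Resting on an at least 3.0-fold higher number from compound 1 to compound 2 (0.48 log units; beyond the scatter), the step of a 2.7-fold higher number from compound 3 to compound 4 (0.43 log units; beyond the scatter) is expected. Compound 4 is thus expected to give about 900 ug/mL, between 400 ug/mL and 3000 ug/mL, and may well return only a limit.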

Compound 4, concentration for 50% inhibition: > 500 ug/mL
Compound 4 was reported as a limit; the forecaster's own chance of this, stated with the estimate: 70%; the middle value is on the limit's open side.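

In this assay, cutting ethyl back to hydrogen on the core of compound 3, the change that turns pentyl into propyl, gives an at least 1.4-fold higher number from compound 3 to compound 4 (0.17 log units; that floor lies within the scatter), and this is only a floor, as compound 4 was reported as a limit. Beside the earlier step, this shows no reversal of direction on the second core, but it does not show that the change carries over with the same size: the same change on two cores in this assay, an at least 3.0-fold higher number (0.48 log units; beyond the scatter) from compound 1 to compound 2 and an at least 1.4-fold higher number (0.17 log units; that floor lies within the scatter) from compound 3 to compound 4; the limit leaves it open whether they differ. The reading is capped on both cores, so neither shortened compound gives a true number: the limit of > 500 ug/mL in this assay, at which 2 of the 4 values shown sit.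

From the compounds shown here alone, it remains open how a longer chain, or an amine at the chain end, would behave on the core of compound 3. The separate contribution of each core also stays unresolved, as compound 1 and compound 3 differ in both core and chain.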